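The source may report more compounds than this note shows. Statements on the series, on what has been measured and on what is new or still open speak of the compounds shown alone.

Going by the values given here, the three compounds measured so far share one core, and none of them has yet given a number. Compound 1 `OB(O)c1ccc2ncnc(Nc3ccc(F)c(Cl)c3)c2c1` in an assay on isolated protein for inhibition of vascular endothelial growth factor receptor 1 (Homo sapiens), read by ELISA, with a stated time of 20 min (a lower number here means a stronger inhibitor, a higher number a weaker inhibitor), gives > 1000 nM, which is a limit of the assay rather than a measured value. Compound 2 `CC1(C)OB(c2ccc3ncnc(Nc4cccc(Cl)c4)c3c2)OC1(C)C` in this assay gives > 1000 nM, again a limit and not a number. Compound 3 `COc1cc2ncnc(Nc3ccc(F)c(Cl)c3)c2cc1B1OC(C)(C)C(C)(C)O1` in this assay gives > 1000 nM, also only a limit. Among the compounds with values here, compound 3 therefore stands exactly where every value shown stands, because the limit of > 1000 nM in this assay, at which 3 of the 3 values shown sit: no compound among the three has reached a measurable value.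

The step to compound 4 `CC1(C)OB(c2ccc3ncnc(Nc4ccc(F)c(Cl)c4)c3c2)OC1(C)C` is hydrogen in place of methoxy on an aromatic carbon. Within the data shown here, no step between two measured compounds is known, so nothing here tells how much a swap of this kind moves a value in this assay; the only shared observation is that all three measured compounds remain beyond the limit. The expected step is a step that the limit leaves unreadable from compound 3 to compound 4, none beyond the scatter. Compound 4 is estimated at 3000 nM, within 1000 nM to 10000 nM, most likely once more reported only as a limit.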

Compound 4, half-maximal inhibitory concentration: > 1000 nM
Compound 4: no number, only a limit; the forecaster's own chance of this, stated with the estimate: 85%; the middle value lies beyond the limit too.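

In this assay compound 4 gives > 1000 nM, again a limit and not a number. Its steps from compound 1, compound 2 and compound 3 therefore cannot be read, because all values share one ceiling: the limit of > 1000 nM in this assay, at which 4 of the 4 values shown sit. The compounds shown leave open how strongly each one actually inhibits the receptor, and whether any of these changes moves that strength.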